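A few compounds are considered here, and "the series" means these few. Any claim that something is new, unique, unknown or untested is made for them only; others in the source may bear on it.

Measured compounds in the series:

Compound 1 `CCCCCCCCCCCCCCC[C@H](O)C[C@@H](O)C[C@@H](O)C[C@@H](O)C[C@@H](O)C[C@H]1CC=CC(=O)O1` gives 4200 nM in a functional assay on HT-29 cells (Homo sapiens) for cytotoxicity, read by MTT assay, with a stated time of 72 h; on this read-out higher numbers stand for weaker inhibition and lower numbers for stronger inhibition.
Compound 2 `CCCCCCCCCCCCCCC[C@@H](C[C@@H](O)C[C@@H](O)C[C@@H](O)C[C@@H](O)C[C@H]1CC=CC(=O)O1)OC(C)=O` gives 2900 nM.
Compound 3 `CCCCCCCCCCCCCCC[C@@H](O)C[C@H](O)C[C@H](O)C[C@H](O)C[C@H](O)C[C@@H]1CC=CC(=O)O1` gives 4100 nM.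

Compound 1 carries the highest of the three numbers, but its nearest neighbour compound 3 sits at a 1.0-fold lower number from compound 1 to compound 3 (0.01 log units; within the scatter), and even compound 2 is only at a 1.4-fold lower number from compound 1 to compound 2 (0.16 log units; within the scatter), so all three stand within the scatter of one another and no order among them can be read. The step from compound 1 to compound 3 rests on (the fact that compounds 1 and 3 differ only in the configuration as drawn); the step from compound 1 to compound 2 is the acetyl in place of hydrogen on an oxygen on a saturated carbon.

Compound 4 `CCCCCCCCCCCCCCC[C@H](O)C[C@@H](O)C[C@@H](O)C[C@@H](O)C[C@@H](O)CCO` is not yet measured. Against compound 1 the change is a group of 2 heavy atoms (1 carbon, 1 oxygen; no ring) in place of a group of 7 heavy atoms (5 carbon, 2 oxygen; one six-membered non-aromatic ring with 1 hetero atom), on a saturated chain carbon, two bonds along the chain from an oxygen on a saturated carbon. Neither measured step bears on this change: one swaps a hydrogen for an acetyl, the other inverts all stereocentres, and both leave the ring with its double bonds untouched. The present change removes that ring entirely and is far larger than anything measured here, so no quantitative anchor exists. The working expectation is a markedly weaker number for compound 4, with a wide range, as an estimated step of a 7.1-fold higher number from compound 1 to compound 4 (0.85 log units; beyond the scatter).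

Compound 4 is therefore expected to give about 30000 nM, estimated between 5000 nM and 200000 nM.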

Compound 4, half-maximal inhibitory concentration: > 1500000 nM
Compound 4: no number, only a limit; the forecaster's own chance of this, stated with the estimate: 35%; middle value at least 50-fold (1.69 log units) away from the limit.
By their numbers in this assay, from the lowest: compounds 2, 3 and 1 (each within the scatter of the next). At a limit, above all of these: compound 4.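

In this assay compound 4 gives > 1500000 nM, which is a limit of the assay and not a number. For the compounds shown here, the series now holds an at least 350-fold higher number from compound 1 to compound 4 (2.55 log units; beyond the scatter), the only step so far beyond the scatter, and its true size stays unknown, since it rests on a bound: the limit of > 1500000 nM in this assay, at which 1 of the 4 values shown sits. Acetyl on an oxygen and inversion of all stereocentres both left the numbers within the scatter, whereas hydroxymethyl in place of the group holding the six-membered non-aromatic ring, on a saturated chain carbon, is a change to which this read-out responds strongly, even with the long chain and the other hydroxyl groups of the core of compound 1 kept.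

The compounds shown swap the whole group in one step, so they do not tell whether the ring itself, its double bonds or its ring oxygen carries the difference, and a version with the ring kept but fully saturated would begin to separate these. Going by these compounds, whether a carboxylic acid or an open-chain ester in place of hydroxymethyl would bring back a measurable number also stays open, as does the effect of a shorter chain at the far end of the core.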